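This account rests on a few compounds, and the source may have more. Where it says the series, first, only, none or still open, it means among the compounds named here.

Working notes on the series.

The series is tested in a functional assay on CCRF-CEM cells for agonist activity at C-X-C chemokine receptor type 4 (Homo sapiens), read by calcium flux, with a stated time of 25 min; on this read-out higher numbers stand for an effect only at larger amounts of compound and lower numbers for an effect already at smaller amounts. Compound 1 `c1cnc2c(c1)CCC[C@@H]2N(CC1CC1)C[C@H]1Cc2c(cccc2N2CCNCC2)CN1` carries an unsubstituted piperazine on the aromatic carbon; in this assay compound 1 gives only a limit, > 30000 nM. Compound 2 `CN(C[C@H]1Cc2c(cccc2N2CCN(C3COC3)CC2)CN1)[C@H]1CCCc2cccnc21` carries the oxetanyl-substituted piperazine at the same place; in this assay compound 2 also gives only a limit, > 30000 nM. Where compound 2 stands on the numbers shown is therefore not a number at all but the limit of the assay, and the same holds for the only other measured compound: the limit of > 30000 nM in this assay, at which 2 of the 2 values shown sit.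

Compound 3 `C[C@@H]1CN(c2cccc3c2C[C@H](CN(C)[C@H]2CCCc4cccnc42)NC3)C[C@H](C)N1` differs from compound 2 in one place: 3,5-dimethylpiperazin-1-yl in place of 4-(oxetan-3-yl)piperazin-1-yl on an aromatic carbon. Among the compounds with values here, no measured step exists between any two compounds, so nothing in the data gives a direction for this change. With compound 1 at > 30000 nM and compound 2 at > 30000 nM, the expectation for compound 3 is that the assay again reports only its limit, and no step beyond the scatter is expected from compound 2 to compound 3 in this assay (a number no higher from compound 2 to compound 3 (the limit leaves the size open)). The estimate for compound 3 in this assay is 30000 nM, with a range from 10000 nM to 100000 nM.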

Compound 3, half-maximal effective concentration: > 30000 nM
Compound 3: a limit, no number; the forecaster's own chance of this, stated with the estimate: 85%; the middle value sits exactly at the limit.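

Within the data shown here, compound 2 and compound 3 both stand at a limit, so no step between them can be read in this assay: the limit of > 30000 nM in this assay, at which 3 of the 3 values shown sit. The compounds shown leave open whether 3,5-dimethylpiperazin-1-yl and 4-(oxetan-3-yl)piperazin-1-yl differ at all in their effect, and what on the shared core would give a value short of the limit.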